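Hydrazide coumarin amides: propoxy in place of diethylamino

The source may report more compounds than this note shows. Statements on the series, on what has been measured and on what is new or still open speak of the compounds shown alone.

Going by the values given here, compound 2 `CCN(CC)c1ccc2cc(C(=O)NN)c(=O)oc2c1` carries the hydrazide; in a functional assay on HeLa cells (Homo sapiens) for cytotoxicity, read by MTT assay, with a stated time of 72 h (a higher number here means a weaker inhibitor, a lower number a stronger inhibitor), compound 2 gives 5480 nM, the only full number in the set. Compound 1 `CCN(CC)c1ccc2cc(C(=O)NC3CC3)c(=O)oc2c1`, the cyclopropyl amide, reaches only a limit in this assay, > 100000 nM, which is a limit and not a number (the limit of > 100000 nM in this assay, at which 1 of the 2 values shown sits). Among the compounds with values here, the step of an at least 18-fold lower number from compound 1 to compound 2 (1.26 log units; beyond the scatter) is the single measured step and concerns the amide-type nitrogen, not the aromatic substituent.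

Compound 3 `CCCOc1ccc2cc(C(=O)NN)c(=O)oc2c1` differs from compound 2 only on the aromatic ring: propoxy in place of diethylamino on an aromatic carbon. Within the data shown here, no measured step touches this place, so the large step on the amide nitrogen offers no guide here. With no comparison for an exchange on the aromatic carbon, the working expectation is a step within scatter in this assay, held with a wide range. Compound 3 is therefore expected at 7000 nM, between 1800 nM and 40000 nM. This corresponds to an expected step of a 1.3-fold higher number from compound 2 to compound 3 (0.11 log units; within the scatter).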

Compound 3, half-maximal inhibitory concentration: > 100000 nM
Compound 3: no number, only a limit; the forecaster's own chance of this, stated with the estimate: 15%; middle value at least 14-fold (1.15 log units) away from the limit.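

With the hydrazide held fixed, the aromatic carbon turns out to be sensitive to exchange: propoxy in place of diethylamino gives an at least 18-fold higher number from compound 2 to compound 3 (1.26 log units; beyond the scatter) in this assay. For compound 3, > 100000 nM is a limit and not a number. Both single exchanges shown from compound 2, one on the amide-type nitrogen and one on the aromatic carbon, end at a limit, which leaves compound 2 as the only compound with a full number in this assay: the limit of > 100000 nM in this assay, at which 2 of the 3 values shown sit.

The compounds shown do not separate a need for diethylamino itself from a need for any amine on this aromatic carbon, a question that a dimethylamino group or a pyrrolidine ring would address. Also open, going by these compounds, is whether a hydroxyl group or a longer alkoxy chain such as butoxy would behave as propoxy does.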